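Adding a Methyl Group to Compound 2

The compounds below may be only part of what the source reports. "The series", "measured", "known", "first", "only" and "open" are said of these compounds alone.

Measured so far:
- compound 1, `CC[C@H](C)[C@H](N)CN(C(=O)[C@@H]1C[C@H]1c1cccnc1)c1ccc(-c2ccccc2)cc1`: 1500 nM
- compound 2, `CC[C@H](C)[C@H](N)CN(C(=O)[C@@H]1C[C@H]1c1nccs1)c1ccc(-c2ccccc2)cc1`: 210 nM

In a functional assay for agonist activity at G protein-coupled receptor 88 (Homo sapiens), read by HTRF and cAMP accumulation (on this read-out higher numbers stand for an effect only at larger amounts of compound and lower numbers for an effect already at smaller amounts), compound 2 gives the lowest of the two numbers, and compound 1 stands well apart from it: the exchange of pyridin-3-yl for 1,3-thiazol-2-yl brought a 7.1-fold lower number from compound 1 to compound 2 (0.85 log units; beyond the scatter).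

Compound 3, `CC[C@H](C)[C@H](N)CN(C(=O)[C@@H]1C[C@H]1c1nc(C)cs1)c1ccc(-c2ccccc2)cc1`, differs from compound 2 only by methyl in place of hydrogen on an aromatic carbon. For the measured compounds named here, no measured step concerns a methyl placed on an aromatic carbon; the single known step, the ring exchange from compound 1 to compound 2, is a different kind of change and offers no direct guide. With nothing to point either way, the addition of one carbon is expected to leave this assay about where compound 2 already stands: the step of a 1.1-fold lower number from compound 2 to compound 3 (0.02 log units; within the scatter) is expected to stay within the scatter. Compound 3 is therefore estimated at 200 nM, with a likely range from 70 nM to 600 nM.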

Compound 3, half-maximal effective concentration: 730 nM
Estimate against measurement, compound 3: 3.7-fold (0.56 log units) below; measured number above the stated range.
By their numbers in this assay, from the lowest: compound 2; then compound 3; then compound 1.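

In this assay, one methyl on the aromatic carbon next to the ring nitrogen is not a neutral addition to the 1,3-thiazol-2-yl group: it gives a 3.5-fold higher number from compound 2 to compound 3 (0.54 log units; beyond the scatter) and so takes back part of what that ring had gained over pyridin-3-yl. The 4-methyl-1,3-thiazol-2-yl group still compares well with pyridin-3-yl, with a 2.1-fold lower number from compound 1 to compound 3 (0.31 log units; beyond the scatter), so this position responds to even a single added carbon without losing the whole benefit of the ring exchange. The data shown offer no measured explanation for this rise.

From the compounds shown here alone, whether an ethyl, a methoxy or an amine on this same carbon would shift the number as methyl does remains open. Going by these compounds, it is also open whether a methyl on another carbon of that ring would have the same effect.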